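The source may hold more compounds than are shown below. What is called first, only, known or untested is meant among the compounds shown, and "the series" means these compounds.

Measured compounds and their values:

Compound 1, `CSc1nc2n(n1)C(c1ccc(O)c(O)c1)C([N+](=O)[O-])=NN2`, 362000 nM
Compound 2, `CSc1nc2n(n1)C(O)C([N+](=O)[O-])=NN2`, 99000 nM
Compound 3, `O=[N+]([O-])C1=CNc2nc(-c3ccco3)nn2C1`, 108000 nM

These three compounds were tested in an ADME assay on MDCK cells (Canis lupus familiaris) for cytotoxicity; on this read-out lower numbers stand for higher toxicity in this test and higher numbers for lower toxicity in this test. Compound 1 gives the highest of the three numbers, at 362000 nM. Its nearest neighbour on the read-out is compound 3 with 108000 nM, a gap that lies beyond the usual scatter, and the furthest is compound 2 with 99000 nM, also beyond the scatter. No pair of these compounds differs in a single place, so no single step has been measured.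

Compound 4, `O=[N+]([O-])C1=NNc2nc(C(F)(F)F)nn2C1c1ccc(O)c(O)c1`, has not yet been tested in this assay. Compared with compound 1 it shows one change: trifluoromethyl in place of methylsulfanyl on an aromatic carbon. Among the measured compounds shown here, with no measured step available for this kind of change, compound 4 is expected to stay close to compound 1, with a step of a 1.4-fold lower number from compound 1 to compound 4 (0.16 log units; within the scatter) that may well remain within the scatter. The expected value for compound 4 is 250000 nM, in a range from 100000 nM to 600000 nM.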

Compound 4, half-maximal cytotoxic concentration: 183000 nM
For compound 4 the middle estimate is 1.4-fold (0.14 log units) above the measured one, within the range that was stated.
By their numbers in this assay, from the lowest: compounds 2, 3, 4 and 1 (each within the scatter of the next, the first and the last beyond it).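

Among the compounds shown here, this is the first single change measured at this position, the aromatic carbon between two ring nitrogen atoms, as the earlier compounds offered no pair differing in one place. In this assay, trifluoromethyl in place of methylsulfanyl gives a 2.0-fold lower number from compound 1 to compound 4 (0.30 log units; within the scatter), so on the core of compound 1 this exchange leaves the read-out indistinguishable from repeated measurement, even though the entering group has more heavy atoms and the sulfur is gone. The data shown offer no measured basis for explaining this result.

Going by these compounds, with one step at this position, it remains open whether the tolerance extends to very different groups, such as an amine, a carboxylic acid or a longer chain. On these data alone, it is equally open whether the same exchange would give a similar step on another core, such as that of compound 2 or compound 3.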